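Swapping cyclohexyl for isopropyl on a flat series

This account rests on a few compounds, and the source may have more. Where it says the series, first, only, none or still open, it means among the compounds named here.

Compound 1 `Cc1cc(Nc2nc(NCc3ccc(F)cc3F)nc3c2cnn3C2CCOCC2)n[nH]1`: 2880 nM
Compound 2 `Cc1cc(Nc2nc(NCc3ccc(F)cc3F)nc3c2cnn3CC(C)(C)O)n[nH]1`: 2510 nM
Compound 3 `Cc1cc(Nc2nc(NCc3ccc(F)cc3F)nc3c2cnn3C2CCCCC2)n[nH]1`: 2960 nM

These three compounds share one core and differ only in the group on an aromatic nitrogen. All were tested in a functional assay on MDA-MB-231 cells (Homo sapiens) for inhibition, read by MTT assay, with a stated time of 5 days; a higher number here means a weaker inhibitor, a lower number a stronger inhibitor. Compound 3, at 2960 nM, cannot be separated from the other two, since its gaps to both lie within the scatter.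

The next compound is compound 4 `Cc1cc(Nc2nc(NCc3ccc(F)cc3F)nc3c2cnn3C(C)C)n[nH]1`, which has isopropyl in place of cyclohexyl on an aromatic nitrogen. The measured steps at this same place bear directly on it. They are a 1.0-fold higher number from compound 1 to compound 3 (0.01 log units; within the scatter), a 1.2-fold higher number from compound 2 to compound 3 (0.07 log units; within the scatter) and a 1.1-fold lower number from compound 1 to compound 2 (0.06 log units; within the scatter), and all three fall within the scatter. Among these compounds, then, replacing the group has not yet moved the number in this assay, even when a ring gave way to an open chain, as in the step between compound 2 and compound 3. Isopropyl is a smaller group than any of these, so some uncertainty remains, but the data give no reason to expect a direction. The expected change is a 1.1-fold lower number from compound 3 to compound 4 (0.02 log units; within the scatter), which would be no step beyond the scatter. For compound 4 the estimated value is 2800 nM, with an expected range from 1600 nM to 4800 nM.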

Compound 4, half-maximal inhibitory concentration: 5350 nM
Compound 4: middle estimate off by 1.9-fold (0.28 log units), on the low side; measured number above the stated range.
By their numbers in this assay, from the lowest: compounds 2, 1, 3 and 4 (each within the scatter of the next, the first and the last beyond it).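

In this assay, this position now gives its first step beyond the scatter: isopropyl in place of 2-hydroxy-2-methylpropyl gives a 2.1-fold higher number from compound 2 to compound 4 (0.33 log units; beyond the scatter) and so a modestly weaker inhibitor, whereas no earlier swap at this place separated two compounds. The two other new steps do not go that far, with a 1.8-fold higher number from compound 3 to compound 4 (0.26 log units; within the scatter) for isopropyl in place of cyclohexyl and a 1.9-fold higher number from compound 1 to compound 4 (0.27 log units; within the scatter) for isopropyl in place of oxan-4-yl, so compound 4 stands apart from compound 2 alone and the group on this nitrogen can matter, if only slightly. Nothing available here accounts for this modest step.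

Going by these compounds, whether a methyl group or a plain hydrogen on this nitrogen would give a still higher number than isopropyl remains open. So does the outcome for a chain ending in an amine or a carboxylic acid, which would show whether this flat stretch of numbers holds for groups of a quite different kind.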